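The source may report more compounds than this note shows. Statements on the series, on what has been measured and on what is new or still open speak of the compounds shown alone.

Of the compounds shown here, three built on a shared core have been tested in a functional assay on SW-620 cells (Homo sapiens) for antiproliferative activity, read by MTT assay, with a stated time of 72 h; a higher number here means a weaker inhibitor, a lower number a stronger inhibitor. Compound 1 `Cc1ccc(-c2cn(C/C=C3\OC(=O)C(OCc4ccccc4)=C3OCc3ccccc3)nn2)cc1` reaches only the limit of > 100000 nM in this assay. Compound 3 `CC(C)(C)OC(=O)N1CCN(C(=S)SCc2cn(C[C@H](O)[C@H]3OC(=O)C(OCc4ccccc4)=C3OCc3ccccc3)nn2)CC1` likewise stops at a limit, > 100000 nM. Compound 1 and compound 3 thus both sit at the limit of > 100000 nM in this assay, at which 2 of the 3 values shown sit. Among the measured compounds shown here, compound 2 `O=C1O[C@H]([C@@H](O)Cn2cc(CNS(=O)(=O)c3ccc(Cl)cc3F)nn2)C(OCc2ccccc2)=C1OCc1ccccc1` gives 42400 nM in this assay, the only actual number among the three. Compound 4 `CCCCCCCCCCc1cn(C[C@H](O)[C@H]2OC(=O)C(OCc3ccccc3)=C2OCc2ccccc2)nn1` has not been measured; it differs from compound 2 in one place: nonyl in place of ((4-chloro-2-fluorophenyl)sulfonyl)amino on a saturated chain carbon bound to an aromatic carbon. For the measured compounds named here, no step between measured compounds is known, so the change can only be judged from compound 2 alone. The step from compound 2 to compound 4 is expected to be modest, a 1.4-fold lower number from compound 2 to compound 4 (0.15 log units; within the scatter), within or just beyond the usual scatter. Compound 4 is estimated at 30000 nM, with a range from 8000 nM to 100000 nM.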

Compound 4, half-maximal inhibitory concentration: 45200 nM
Compound 4: the middle estimate sits 1.5-fold (0.18 log units) below what was measured, within the range that was stated.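

At this place, on a saturated chain carbon bound to an aromatic carbon, nonyl replaces ((4-chloro-2-fluorophenyl)sulfonyl)amino with a 1.1-fold higher number from compound 2 to compound 4 (0.03 log units; within the scatter) in this assay, so the two compounds read alike. The aromatic ring and the hydrogen-bond donor and acceptors of the group that leaves are therefore not required for a measurable number here, since a chain with none of them matches it. Nothing shown explains why such different groups read alike.

From the compounds shown here alone, whether an amine, a carboxylic acid or a shorter chain at this place would change the number remains open. So does whether any group here can give a clearly stronger inhibitor.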